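The compounds below may be only part of what the source reports. "The series", "measured", "known", "first", "only" and "open" are said of these compounds alone.

Of the compounds shown here, two with a shared core have been measured in a physicochemical assay for solubility; on this read-out lower numbers stand for lower solubility and higher numbers for higher solubility. Compound 1, `CNC(=O)c1cc(C(=O)NC2CCC2)cn(Cc2ccncc2)c1=O`, gives in this assay a reading that is a limit of the assay rather than a number, >= 118 ug/mL. Compound 2, `CNC(=O)c1cc(C(=O)NCCC2CCOCC2)cn(Cc2ccccc2)c1=O`, likewise gives only a limit in this assay, >= 127 ug/mL. Compound 2 thus stands at the upper edge of what this assay reports, and how far its solubility reaches beyond that edge is not known. The reading for compound 1 is of the same kind, (the limit of >= 118 ug/mL in this assay, at which 1 of the 2 values shown sits). Compound 3, `CNC(=O)c1cc(C(=O)NCC(C)C)cn(Cc2ccccc2)c1=O`, has not yet been measured. It differs from compound 2 in one place: isopropyl in place of (oxan-4-yl)methyl on a saturated chain carbon bound to an amide-type nitrogen. Among the measured compounds shown here, no measured pair of compounds shows the effect of such a change, so its size is open. The expected step is small, an at least 1.1-fold lower number from compound 2 to compound 3 (0.06 log units; that floor lies within the scatter), within the usual scatter. Compound 3 is expected to give about 110 ug/mL in this assay, in a range from 50 ug/mL to 220 ug/mL.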

Compound 3, solubility: 43 ug/mL
The estimate for compound 3 lay 2.6-fold (0.41 log units) above the measured number; measured number below the stated range.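

In this assay, isopropyl in place of (oxan-4-yl)methyl on a saturated chain carbon bound to an amide-type nitrogen gives an at least 2.9-fold lower number from compound 2 to compound 3 (0.47 log units; beyond the scatter). Among the compounds shown here, this is the first pair differing in one place, and it shows that a change at this position can move the read-out beyond the usual scatter. The true step may be larger, and it can be given only as a minimum because compound 2 gives a limit of the assay rather than a number: the limit of >= 127 ug/mL in this assay, at which 1 of the 3 values shown sits.

The departing group's ring and its oxygen, a hydrogen-bond acceptor, leave together, so this pair cannot show which of them matters. Going by these compounds, a cyclohexylmethyl group would keep the ring without the oxygen, while an amine or a longer chain at this place remains unexplored in this assay.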